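The source may hold more compounds than are shown below. What is called first, only, known or untested is meant among the compounds shown, and "the series" means these compounds.

Measured compounds in a functional assay on MCF7 cells (Homo sapiens) for cytotoxicity, read by CellTiter-Glo, with a stated time of 5 days; on this read-out higher numbers stand for weaker inhibition and lower numbers for stronger inhibition:
- compound 1 `COC/C(=C(/c1ccc(/C=C/C(=O)O)cc1)c1ccc2[nH]ncc2c1)c1ccccc1`: 88 nM
- compound 2 `O=C(O)/C=C/c1ccc(/C(=C(\c2ccccc2)C2CCC2)c2ccc3[nH]ncc3c2)cc1`: 1.4 nM
- compound 3 `CC/C(=C(/c1ccc(/C=C/C(=O)O)cc1)c1cnc2[nH]ncc2c1)c1ccccc1`: 302 nM

Compound 3 gives the highest number of the three in this assay; compound 1 is nearest, compound 2 furthest. Compound 4 `CC/C(=C(/c1ccc(/C=C/C(=O)O)cc1)c1ccc2[nH]ncc2c1F)c1ccccc1` differs from compound 3 by a group of 10 heavy atoms (7 carbon, 2 nitrogen, 1 fluorine; one five-membered aromatic ring with 2 hetero atoms, one six-membered aromatic ring of carbon only) in place of a group of 9 heavy atoms (6 carbon, 3 nitrogen; one five-membered aromatic ring with 2 hetero atoms, one six-membered aromatic ring with 1 hetero atom), on a double-bonded chain carbon bound to an aromatic carbon and a double-bonded chain carbon. Among the compounds with values here, the only recorded step, a 63-fold lower number from compound 1 to compound 2 (1.80 log units; beyond the scatter), concerns a different position and does not bear on this change. Compound 1 and compound 3 differ in two places, so their values offer only a loose pointer: the compound carrying the six-membered ring of carbon only gives the lower number. On that basis a moderate downward step is expected, an 8.6-fold lower number from compound 3 to compound 4 (0.94 log units; beyond the scatter). Compound 4 is estimated at 35 nM (range 8 nM to 150 nM).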

Compound 4, half-maximal inhibitory concentration: 3 nM
For compound 4 the middle estimate is 12-fold (1.07 log units) above the measured one; the measured number lies below the stated range.
By their numbers in this assay, from the lowest: compound 2; then compound 4; then compound 1; then compound 3.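

In this assay, the group on a double-bonded chain carbon bound to an aromatic carbon and a double-bonded chain carbon proves a strong lever: 4-fluoro-1H-indazol-5-yl gives a 100-fold lower number from compound 3 to compound 4 (2.00 log units; beyond the scatter). The number therefore moves sharply at this position as well, not only at the position changed in the earlier step. No measurement on hand accounts for this step.

The change combines the fluorine with a six-membered ring of carbon only, and the compounds shown do not separate the two. Going by these compounds, whether a chlorine or a methyl group in place of the fluorine would give a similar number remains open.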